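A few compounds are considered here, and "the series" means these few. Any claim that something is new, unique, unknown or untested is made for them only; others in the source may bear on it.

In an ADME assay on Huh-7 cells (Homo sapiens) for cytotoxicity, read by MTT assay, with a stated time of 96 h (on this read-out higher numbers stand for lower toxicity in this test and lower numbers for higher toxicity in this test), compound 1 `COc1cc(NCc2ccc(C)o2)ccc1-c1cnco1` gives 63400 nM and compound 2 `COc1ccc(-c2cnco2)cc1NCc1ccc(C)s1` gives 52900 nM, two values within the usual scatter of each other. Compound 3 `COc1cc(/N=C/c2ccc(F)cc2)ccc1-c1cnco1` is reported only as a limit, > 100000 nM. Compound 4 `COc1cc(NCc2ccc(Br)s2)ccc1-c1cnco1` has not yet been measured. It keeps the core of compound 1 but has 5-bromothiophen-2-yl in place of 5-methylfuran-2-yl on a saturated chain carbon bound to a nitrogen on an aromatic ring. Going by the values given here, no measured pair shows this exact change, so no step beyond the scatter is expected in this assay. The expected change is small: a 1.3-fold lower number from compound 1 to compound 4 (0.10 log units; within the scatter). For compound 4, the estimated value is 50000 nM, with an expected range from 20000 nM to 100000 nM.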

Compound 4, half-maximal cytotoxic concentration: 39400 nM
For compound 4 the middle estimate is 1.3-fold (0.10 log units) above the measured one; measured number inside the range.
By their numbers in this assay, from the lowest: compounds 4, 2 and 1 (each within the scatter of the next). At a limit, above all of these: compound 3.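

Going by these compounds alone, putting 5-bromothiophen-2-yl in place of 5-methylfuran-2-yl gives a 1.6-fold lower number from compound 1 to compound 4 (0.21 log units; within the scatter), the first step measured between compounds that differ in one place. At this position, then, the exchange leaves no change that can be told from repeat variation in this test. No measured result here gives a cause for the size of this step.

Ring and substituent change together, so their separate contributions stay unknown. Also open, on these data alone, is how a carboxylic acid or an amine in place of the bromine would read in this test.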